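Dropping the carbamoyl: what happens to compound 1

The source may hold more compounds than are shown below. What is called first, only, known or untested is meant among the compounds shown, and "the series" means these compounds.

Compound 1 `CCOc1ccc(Br)cc1-c1cc(Nc2ccc(C(N)=O)cc2)nc(N)n1`: 750 nM
Compound 2 `CCOc1ccc(Cl)cc1-c1cc(Nc2ccc3c[nH]nc3c2)nc(N)n1`: 24 nM

In an assay on Sf9 cells for inhibition of 1-acyl-sn-glycerol-3-phosphate acyltransferase beta (Homo sapiens) (on this read-out lower numbers stand for stronger inhibition and higher numbers for weaker inhibition), compound 1 gives 750 nM, the highest of the two numbers; compound 2 gives 24 nM, a gap beyond the scatter. Compound 3 `CCOc1ccc(Br)cc1-c1cc(Nc2ccccc2)nc(N)n1` differs from compound 1 by hydrogen in place of carbamoyl on an aromatic carbon, on an aromatic carbon para to a large group. Among the compounds with values here, no step between measured compounds isolates this change, so the expectation rests on compound 1 alone. A modest weakening is expected, as the step from compound 1 to compound 3 of a 2.0-fold higher number from compound 1 to compound 3 (0.30 log units; within the scatter). Compound 3 is therefore estimated at 1500 nM, within 400 nM to 6000 nM.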

Compound 3, half-maximal inhibitory concentration: 120 nM
Estimate against measurement, compound 3: 13-fold (1.10 log units) above, and the stated range ends above it.
By their numbers in this assay, from the lowest: compound 2; then compound 3; then compound 1.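

In this assay, the carbamoyl at this spot on the phenyl ring proves unnecessary for inhibition: replacing it with hydrogen gives a 6.3-fold lower number from compound 1 to compound 3 (0.80 log units; beyond the scatter), a step beyond the usual scatter. A bare phenyl is therefore the better of the two, and the position tolerates losing the whole group. No available evidence explains this gain.

The position has so far been compared with only carbamoyl and hydrogen. Going by these compounds, how a smaller group such as an amine, or a carboxylic acid, would compare with hydrogen remains open.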